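The compounds below may be only part of what the source reports. "The series", "measured", "known", "first", "only" and "open" are said of these compounds alone.

Measured compounds in a functional assay on UACC-62 cells (Homo sapiens) for cytotoxicity, read by sulforhodamine B assay, with a stated time of 48 h, tested at 100 uM; a higher number here means a weaker effect of the compound at the concentration tested, a lower number a stronger effect:

compound 1 `COc1ccc(-c2cc(/C=C/C(=O)c3ccc(N)cc3)[nH]n2)cc1` gives -93%
compound 2 `COc1cc(-c2cc(/C=C/C(=O)c3ccc(N)cc3)[nH]n2)cc(OC)c1OC` gives -92%
compound 3 `COc1ccc(C(=O)/C=C/c2cc(-c3cc(OC)c(OC)c(OC)c3)n[nH]2)cc1OC` gives -93%

The three numbers sit within the scatter of one another. Compound 2 holds the highest of the three, but its nearest neighbour compound 1 and its furthest neighbour compound 3 each lie within the scatter, so the set gives no separation among them.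

The step from compound 2 to compound 4 `COc1ccc(-c2cc(/C=C/C(=O)c3ccc(N)cc3)[nH]n2)cc1OC` is a small change: hydrogen in place of methoxy on an aromatic carbon. Among the measured compounds shown here, the only measured step in this assay is a number 1 percentage points lower from compound 2 to compound 3 (within the scatter), which alters the aryl on the carbonyl carbon rather than the aryl on the shared core, and it stays within the scatter. For the measured compounds named here, no measured step touches the methoxy pattern of the aryl on the core; the values of compound 1 and compound 2, which carry different methoxy patterns there, simply show the same number. Compound 4 carries a pattern between these two. The expectation for compound 4 is therefore a step of no change at the digits printed from compound 2 to compound 4 (within the scatter) in this assay, nothing beyond the scatter. Compound 4 is estimated at -92%, within a range from -100% to -80%.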

Compound 4, a percentage reported as activity, at one concentration (the size of the read-out at that concentration, not a potency): -86%
For compound 4 the middle estimate is 6 percentage points below the measured one; the range from low to high includes it.
By their numbers in this assay, from the lowest: compounds 1, 3, 2 and 4 (each within the scatter of the next).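

In this assay the methoxy on this aromatic carbon, ortho to a methoxy group and meta to a large group, can now be read as a single change: hydrogen in place of methoxy gives a number 6 percentage points higher from compound 2 to compound 4 (within the scatter) and stays within the scatter. On the other side of compound 4, methoxy in place of hydrogen on an aromatic carbon gives a number 7 percentage points higher from compound 1 to compound 4 (within the scatter) and also stays within the scatter. So each single methoxy change on the aryl of the shared core leaves the read-out unresolved at this one concentration, and no measurement on hand explains the sizes of these steps.

From the compounds shown here alone, whether a hydroxy group, a chlorine or a longer ethoxy chain on this carbon would move the read-out beyond the scatter remains open. Going by these compounds, a reading at one concentration also gives no potency, so any differences among compounds 1, 2 and 4 at lower concentrations remain unknown.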